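Four Alkyne-Linked Cyclic Ureas Tested in Mice

The compounds below may be only part of what the source reports. "The series", "measured", "known", "first", "only" and "open" are said of these compounds alone.

Compound 1, with the structure `O=C1NCCN1CC#CCn1ccnc1`, carries a five-membered cyclic urea joined through a short alkyne chain to an imidazole. Compound 2, `CN(C)CC#CCN1CCNC1=O`, keeps that core. In a functional assay on the whole organism for antagonist activity, with Mus musculus as the target (on this read-out higher numbers stand for an effect only at larger amounts of compound and lower numbers for an effect already at smaller amounts), compound 1 gives only a limit, > 100 mg/kg. In this assay compound 2 likewise gives only a limit, > 100 mg/kg. The change between the two is dimethylamino in place of 1H-imidazol-1-yl on a saturated chain carbon bound to a triple-bonded carbon, and the step it made is a step that the two limits leave unreadable from compound 1 to compound 2.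

Compound 3, `Cn1ccn(CC#CCn2ccnc2)c1=O`, rests on a different core; how that core differs from the core of compound 1 is not broken down here. In this assay compound 3 also gives only a limit, > 100 mg/kg. All three values share the same situation: the limit of > 100 mg/kg in this assay, at which 3 of the 3 values shown sit.

Compound 4, `CN(C)CC#CCn1ccn(C)c1=O`, is not yet measured. It arises from compound 3 by the same change seen earlier: dimethylamino in place of 1H-imidazol-1-yl on a saturated chain carbon bound to a triple-bonded carbon. The place of the change is the same in both pairs.

Because the earlier step that the two limits leave unreadable from compound 1 to compound 2 could not be read, and because every measured compound sits at the limit of > 100 mg/kg in this assay, at which 3 of the 3 values shown sit, the step from compound 3 to compound 4 is expected to be a step that the limit leaves unreadable from compound 3 to compound 4. Compound 4 is therefore expected to give about 200 mg/kg in this assay. The expected range for compound 4 runs from 50 mg/kg to 1000 mg/kg, and most likely the measurement will again stop at a limit.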

Compound 4, dose for half-maximal effect: > 100 mg/kg
Compound 4 was reported as a limit; the forecaster's own chance of this, stated with the estimate: 85%; the middle value does not contradict the limit.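

For the compounds shown here, compound 3 and compound 4 both stop at a limit, so no step between them can be read, and this result adds no new step. All the compounds shown share one situation: the limit of > 100 mg/kg in this assay, at which 4 of the 4 values shown sit.

They leave open what dose for half-maximal effect any of them has in this assay, and so whether dimethylamino in place of 1H-imidazol-1-yl changes that dose at all.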